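This account rests on a few compounds, and the source may have more. Where it says the series, first, only, none or still open, it means among the compounds named here.

Among the measured compounds shown here, in a functional assay on the whole organism with Rattus norvegicus as the target, at a dose of 40 mg/kg by the intraperitoneal route (on this read-out higher numbers stand for more inhibition at the one dose given (going by the name of the read-out) and lower numbers for less inhibition), compound 3 `CNc1c(C)nc2c(OCc3ccccc3)cccn12` gives 55%, the second highest of the three numbers known: compound 1 `Cc1nc2c(OCc3ccccc3)cccn2c1CN` gives 46%, and compound 2 `CC(=O)Nc1c(C)nc2c(OCc3ccccc3)cccn12` gives 93%. Compound 4 `CCCN(CCC)c1c(C)nc2c(OCc3ccccc3)cccn12` differs from compound 3 by dipropylamino in place of methylamino on an aromatic carbon. For the measured compounds named here, two measured steps concern the same aromatic carbon: a number 9 percentage points higher from compound 1 to compound 3 (within the scatter), and a number 38 percentage points lower from compound 2 to compound 3 (beyond the scatter). Going by the values given here, neither of them replaces a small group on that carbon with a larger one of the same kind, so there is no direct precedent, and the one large step seen there involves compound 2 and its acetyl group. For compound 4 the expected step is a number 5 percentage points lower from compound 3 to compound 4 (within the scatter), none beyond the scatter. Compound 4 is therefore estimated at 50%, in the range 25% to 80%.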

Compound 4, a percentage reported as inhibition, in the whole organism at one dose (the size of the read-out at that dose, not a potency): 60%
For compound 4 the middle estimate is 10 percentage points below the measured one; measured number inside the range.
By their numbers in this assay, from the lowest: compounds 1, 3 and 4 (each within the scatter of the next, the first and the last beyond it); then compound 2.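

In this assay, dipropylamino in place of methylamino gives a number 5 percentage points higher from compound 3 to compound 4 (within the scatter), so on this aromatic carbon the much larger dialkylamino group, with no hydrogen-bond donor, reads the same as methylamino. Acetamido remains apart from both amines, with a number 33 percentage points lower from compound 2 to compound 4 (beyond the scatter), while a number 14 percentage points higher from compound 1 to compound 4 (beyond the scatter) is the first step away from aminomethyl that lies beyond the scatter. Nothing measured here explains these differences. Open, as far as these compounds go, is whether a propionamido group or a urea on this carbon would keep the value of compound 2, 93%, and whether a cyclic amine such as piperidine would read like dipropylamino.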